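This account rests on a few compounds, and the source may have more. Where it says the series, first, only, none or still open, it means among the compounds named here.

Series notes, a functional assay for agonist activity at G protein-coupled receptor 88 (Homo sapiens), read by HTRF and cAMP accumulation; a lower number here means that less compound is needed, a higher number that more compound is needed for the effect:
compound 1 `CC(C)CCCN(C(=O)[C@@H]1C[C@H]1c1ccccc1)c1ccc(-c2ccccc2)cc1` gives > 100 nM, a limit of the assay.
compound 2 `CC(C)(N)CN(C(=O)[C@@H]1C[C@H]1c1ccccc1)c1ccc(-c2ccccc2)cc1` gives 1.4 nM.
compound 3 `CC[C@H](C)[C@H](N)CN(C(=O)[C@@H]1C[C@H]1c1ccc(OC)cc1)c1ccc(-c2ccccc2)cc1` gives > 25000 nM, again a limit.

Compound 3 stands at the high end of the three results: its value in this assay is only a limit, namely (the limit of > 25000 nM in this assay, at which 1 of the 3 values shown sits), so no number is known for it. Compound 1 likewise sits at a limit, (the limit of > 100 nM in this assay, at which 1 of the 3 values shown sits). Within the data shown here, compound 2 is the one compound of the three with a finite value.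

Compound 4 `CC[C@H](C)[C@H](N)CN(C(=O)[C@@H]1C[C@H]1c1ccoc1)c1ccc(-c2ccccc2)cc1` keeps the whole of compound 3 except one change: furan-3-yl in place of 4-methoxyphenyl on a saturated ring carbon. Among the measured compounds shown here, the only measured step, an at least 71-fold lower number from compound 1 to compound 2 (1.85 log units; beyond the scatter), concerns a different place, the chain on the amide-type nitrogen, and leaves the ring on the three-membered ring carbon untouched; compounds 1 and 2 both carry plain phenyl there. For the measured compounds named here, no measured step bears on the change from compound 3 to compound 4, so no direction can be read off, and nothing in the data says the change would bring compound 3 off its limit. The expectation is therefore a step of about a number no higher from compound 3 to compound 4 (the limit leaves the size open), i.e. none beyond the scatter. For compound 4 the expected value in this assay is 25000 nM, with a range from 3000 nM to 150000 nM, and most likely the assay again reports only a limit.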

Compound 4, half-maximal effective concentration: 580 nM
For compound 4 the middle estimate is 43-fold (1.63 log units) above the measured one, and the stated range ends above it.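

In this assay, among these compounds, the group on the saturated ring carbon of the three-membered ring turns out to matter: furan-3-yl in place of 4-methoxyphenyl gives an at least 43-fold lower number from compound 3 to compound 4 (1.63 log units; beyond the scatter), the only measured step at this position. Compound 3 has no number, so this step gives only a lower bound on the size of the change: the limit of > 25000 nM in this assay, at which 1 of the 4 values shown sits. Compound 4 has a finite value of 580 nM, which also shows that the chain on the amide-type nitrogen shared by compounds 3 and 4 does not by itself prevent a measured number.

The pair cannot separate the effect of losing the methoxy group from that of replacing the six-membered aromatic ring with a five-membered one, a question that plain phenyl or thiophen-3-yl at this place, on the chain of compound 4, would address. Among the compounds shown here, also open is how that chain compares with the one in compound 2 when the group on the three-membered ring is held the same, and whether other five-membered aromatic rings, such as furan-2-yl or thiazol-5-yl, behave like furan-3-yl.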